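The compounds below may be only part of what the source reports. "The series", "measured", "known", "first", "only" and "open" are said of these compounds alone.

Measured so far in an ADME assay on the whole organism for inhibition, with Echinochloa crus-galli var. formosensis as the target, with a stated time of 4 days; on this read-out higher numbers stand for weaker inhibition and lower numbers for stronger inhibition:
- Compound 1 `CC[C@H](C)Nc1nc(Cl)nc(N[C@H](C)c2ccccc2)n1`: 52500 nM
- Compound 2 `CCCN(C)c1nc(Cl)nc(N[C@H](C)c2ccccc2)n1`: 9770 nM
- Compound 3 `CC(C)Nc1nc(Cl)nc(N[C@@H](C)c2ccccc2)n1`: 11000 nM

Compound 3 sits level with compound 2, within the usual scatter, and its number is lower than that of compound 1 by more than the scatter. The next compound to consider is compound 4 `CC(C)Nc1nc(Cl)nc(N[C@H](C)c2ccccc2)n1`, and the change is this: the two compounds have the same atoms and bonds and differ only in configuration as drawn: 1 of 1 stereo elements differ; a stereocentre at a saturated chain carbon is drawn S in compound 3 and R in compound 4. No atom or bond differs, only the configuration as drawn.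

For the measured compounds named here, no measured pair inverts this stereocentre, so the data offer no direct guide. Going by the values given here, the only measured step lies elsewhere in the molecule, a 5.4-fold lower number from compound 1 to compound 2 (0.73 log units; beyond the scatter), and it shows that a single change in this small set can move this assay beyond the scatter. Compound 1 and compound 2 are drawn with the same configuration at this carbon as compound 4, but that alone settles no direction. A somewhat smaller step towards a lower number is therefore only a tentative lean.

The estimated step is a 2.8-fold lower number from compound 3 to compound 4 (0.44 log units; beyond the scatter). For compound 4 the expected value is 4000 nM, with an estimated range from 800 nM to 20000 nM.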

Compound 4, half-maximal inhibitory concentration: 2000 nM
The estimate for compound 4 lay 2.0-fold (0.30 log units) above the measured number, and the stated range covers the measured number.
By their numbers in this assay, from the lowest: compound 4; then compounds 2 and 3 (each within the scatter of the next); then compound 1.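

In this assay, for the compounds shown here, inverting the stereocentre at the saturated chain carbon gives a 5.5-fold lower number from compound 3 to compound 4 (0.74 log units; beyond the scatter), the first direct evidence that configuration at this carbon matters, with the R drawing giving the lower number. This step can be tied to the stereocentre alone because nothing else changes: the fact that compounds 3 and 4 differ only in the configuration as drawn. With that R drawing kept, the amino group matters too: isopropylamino in place of methyl(propyl)amino gives a 4.9-fold lower number from compound 2 to compound 4 (0.69 log units; beyond the scatter), and hydrogen in place of methyl, which turns the sec-butyl chain into isopropyl, gives a 26-fold lower number from compound 1 to compound 4 (1.42 log units; beyond the scatter), the largest step in this set.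

As far as these compounds go, it remains open whether inverting the same carbon would move the number as far with sec-butylamino or methyl(propyl)amino on the shared core. From the compounds shown here alone, how an ethylamino or cyclopropylamino group would compare with isopropylamino also remains open.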